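Cytotoxicity of aldehyde peptidomimetics: a carbamate swap

The source may report more compounds than this note shows. Statements on the series, on what has been measured and on what is new or still open speak of the compounds shown alone.

Measured compounds and their values in an ADME assay on Vero C1008 cells (Chlorocebus sabaeus) for cytotoxicity, read by luminescence and CellTiter-Glo, with a stated time of 24 h; on this read-out higher numbers stand for lower toxicity in this test and lower numbers for higher toxicity in this test:
- compound 1 `O=C[C@H](C[C@@H]1CCNC1=O)NC(=O)[C@H](CC1CC1)NC(=O)OCc1ccccc1`: > 200000 nM
- compound 2 `CC(C)C[C@H](NC(=O)O[C@@H](C)c1ccccc1)C(=O)N[C@H](C=O)C[C@@H]1CCNC1=O`: > 200000 nM
- compound 3 `O=C[C@H](C[C@@H]1CCNC1=O)NC(=O)[C@H](CC1CC1)NC(=O)OCc1cccc(F)c1`: > 200000 nM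

In this assay compound 1 gives only a limit, > 200000 nM. Compound 2 likewise gives only a limit, > 200000 nM. Compound 3 also gives only a limit, > 200000 nM. So compound 3 stands at the limit of this assay, and the two other values shown stand there as well (the limit of > 200000 nM in this assay, at which 3 of the 3 values shown sit).

Among the compounds with values here, the only step between measured compounds that differ in one place is a step that the two limits leave unreadable from compound 1 to compound 3; because both ends of it are limits, its size cannot be read.

Compound 4 `C[C@H](OC(=O)N[C@@H](CC1CC1)C(=O)N[C@H](C=O)C[C@@H]1CCNC1=O)c1ccccc1` differs from compound 3 by 1-phenylethyl in place of 3-fluorobenzyl on an oxygen next to a carbonyl group. Within the data shown here, the single measured step that could bear on this change is unreadable, and compound 2, which carries the entering group on a different side chain, also sits at the limit (the limit of > 200000 nM in this assay, at which 3 of the 3 values shown sit). Among the measured compounds shown here, nothing among the measured compounds therefore points to a step beyond the scatter in this assay. Compound 4 is expected to stand at the limit once more, an expected step of a number no higher from compound 3 to compound 4 (the limit leaves the size open). The estimate for compound 4 in this assay is 200000 nM, with a range from 100000 nM to 400000 nM.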

Compound 4, half-maximal cytotoxic concentration: > 200000 nM
Compound 4 gave a limit, no number (the forecaster's own chance of this, stated with the estimate: 85%); the middle value sits exactly at the limit.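

In this assay compound 4 gives > 200000 nM as a limit and not a number. The steps to compound 4 from compound 1, compound 2 and compound 3 therefore cannot be read, and all four compounds share one limit: the limit of > 200000 nM in this assay, at which 4 of the 4 values shown sit. The compounds shown leave open at what concentration any of them harms these cells, and whether any of these changes would shift it.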